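A few compounds are considered here, and "the series" means these few. Any claim that something is new, unique, unknown or untested is made for them only; others in the source may bear on it.

Measured compounds:
- compound 1, `CCOC(=O)CNc1nc(-n2nc(-c3ccccn3)nc2N)c2cc(OC)c(OC)cc2n1`: 48000 nM
- compound 2, `COc1cc2nc(N)nc(-n3nc(-c4ccccn4)nc3N)c2cc1OC`: 27000 nM
- compound 3, `COc1cc2ncnc(-n3nc(-c4ccccn4)nc3N)c2cc1OCCCN(C)C`: 53000 nM

These three compounds share a core and were each measured in a physicochemical assay for solubility, in phosphate buffer, with a stated time of 18 h, at pH 7.4; a lower number here means a less soluble compound, a higher number a more soluble compound. Compound 3 gives 53000 nM, and that number lies within the usual scatter of both compound 1 and compound 2, so compound 3 does not stand apart from either of them on the numbers shown.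

The next compound, compound 4, is `COc1cc2ncnc(-n3nc(-c4ccccn4)nc3N)c2cc1OCCCNC(=O)OCC(C)(C)C`. It differs from compound 3 in one place:

(neopentyloxycarbonyl)amino in place of dimethylamino on a saturated chain carbon, three bonds along the chain from an oxygen on an aromatic ring

Within the data shown here, only one measured step exists among the three compounds, a 1.8-fold lower number from compound 1 to compound 2 (0.25 log units; within the scatter), and it concerns a different part of the molecule, a nitrogen on an aromatic ring rather than the saturated chain that carries the changed group. Among the measured compounds shown here, no measured step touches the chain end where compound 4 differs from compound 3. For the measured compounds named here, the one step that exists was within the scatter, so the numbers so far give no direct guide for this change, and any expectation rests on the change itself rather than on a matching measured step.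

On that basis the expected step for compound 4 is a 6.6-fold lower number from compound 3 to compound 4 (0.82 log units; beyond the scatter), a lower number in this assay. Compound 4 is therefore estimated at 8000 nM, with a range from 1500 nM to 30000 nM.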

Compound 4, solubility: 200 nM
Beside the measured number, compound 4's estimate is 40-fold (1.60 log units) above it; measured number outside the range, below it.
By their numbers in this assay, from the lowest: compound 4; then compounds 2, 1 and 3 (each within the scatter of the next).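

In this assay, the end of this chain proves to be a place where one change can move the number far: (neopentyloxycarbonyl)amino in place of dimethylamino gives a 270-fold lower number from compound 3 to compound 4 (2.42 log units; beyond the scatter). Among these compounds, the earlier compounds could not show this, as their only step, a 1.8-fold lower number from compound 1 to compound 2 (0.25 log units; within the scatter), concerns a nitrogen on an aromatic ring and not the saturated chain. The swap alters several things at once, since the entering group has more heavy atoms, adds a double bond outside the aromatic rings and brings a hydrogen-bond donor, and nothing measured here connects the fall in the number to any one of these features.

What remains open is which part of the entering group accounts for the step: a small acetylamino group or a methoxycarbonylamino group at the same chain end would help separate the carbonyl-bearing link from the bulky neopentyl part. From the compounds shown here alone, it is also open whether a primary amine, a carboxylic acid or a shorter or longer chain at this position would give a number nearer to that of compound 3 or that of compound 4.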